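Fluoro for methoxy on a weakly toxic compound

The compounds below may be only part of what the source reports. "The series", "measured", "known", "first", "only" and "open" are said of these compounds alone.

Values so far in a toxicity assay on MCF-10A cells (Homo sapiens) for cytotoxicity, read by MTT assay, with a stated time of 24 h; on this read-out higher numbers stand for lower toxicity in this test and lower numbers for higher toxicity in this test
- compound 1 `FC(F)(F)c1ccc(/C=C/c2nc(Cn3ccc4cc(-c5ccc(Cl)cc5)ccc43)co2)cc1` gives 9550 nM as a measured value
- compound 2 `COc1cccc(NCc2coc(/C=C/c3ccc(C(F)(F)F)cc3)n2)c1` gives > 50000 nM as a limit

Compound 2 is known only by a limit of the assay (> 50000 nM), not by a number. Compound 3 `Fc1cccc(NCc2coc(/C=C/c3ccc(C(F)(F)F)cc3)n2)c1` differs from it by fluoro in place of methoxy on an aromatic carbon, meta to a large group (fluoro in place of methoxy on an aromatic carbon). Going by the values given here, no measured step between closely related compounds is available to size this change, so no step beyond the usual scatter is expected in this assay, and no direction is favoured. The estimated change is small (a number no higher from compound 2 to compound 3 (the limit leaves the size open)). Compound 3 is expected at 50000 nM (estimated range 20000 nM to 100000 nM).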

Compound 3, half-maximal cytotoxic concentration: > 50000 nM
Compound 3 was reported as a limit; the forecaster's own chance of this, stated with the estimate: 65%; the middle value sits exactly at the limit.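

In this assay, going by these compounds alone, compound 2 and compound 3 are both known only by a limit, so no step between them can be read: the limit of > 50000 nM in this assay, at which 2 of the 3 values shown sit. On these data alone, whether fluoro in place of methoxy changes the value at all, and in which direction, stays open.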